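Growth inhibition notes: chloro for fluoro on compound 2

The source may hold more compounds than are shown below. What is called first, only, known or untested is meant among the compounds shown, and "the series" means these compounds.

Measured compounds:
compound 1 `N=C(N)c1ccc(-c2ccc(-c3cncc4ccccc34)s2)s1`: 1550 nM
compound 2 `N=C(N)c1ccc(-c2ccc(-c3ccc(F)cc3)o2)o1`: 1800 nM

In a functional assay on DU-145 cells (Homo sapiens) for inhibition, read by sulforhodamine B assay, with a stated time of 48 h (a higher number here means a weaker inhibitor of growth, a lower number a stronger inhibitor of growth), compound 1 gives 1550 nM, and compound 2 gives 1800 nM. Among the measured compounds shown here, compound 2 carries the higher of the two numbers, but its gap to compound 1 lies within the scatter, so the two values show no order between them; the two compounds differ in several places, and no single-point step connects them.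

Compound 3 `N=C(N)c1ccc(-c2ccc(-c3ccc(Cl)cc3)o2)o1` has not been measured. It differs from compound 2 by chloro in place of fluoro on an aromatic carbon. For the measured compounds named here, no measured pair shows a step of this kind, so there is nothing in the set to size it from. The expectation is a step in this assay of no more than the scatter, if anything toward a slightly lower number: the expected step is a 1.3-fold lower number from compound 2 to compound 3 (0.11 log units; within the scatter). For compound 3 the estimate in this assay is 1400 nM, with a range from 550 nM to 3600 nM.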

Compound 3, concentration for 50% growth inhibition: 1750 nM
For compound 3 the middle estimate is 1.3-fold (0.10 log units) below the measured one, and the stated range covers the measured number.
By their numbers in this assay, from the lowest: compounds 1, 3 and 2 (each within the scatter of the next).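

In this assay the step reads a 1.0-fold lower number from compound 2 to compound 3 (0.01 log units; within the scatter) for chloro in place of fluoro on an aromatic carbon, para to a large group. Among the compounds shown here, the earlier compounds offered no single-point step, and this pair now gives a first reading at this position: the two halogens cannot be told apart here, so the exchange of one for the other leaves growth inhibition unchanged within the scatter. Nothing in hand offers an explanation for this result.

As far as these compounds go, whether the position stays this flat for a group other than a halogen remains open, and an amine, a methoxy group or a carboxylic acid in the same place would test that. From the compounds shown here alone, how a single-point change elsewhere on the shared core would read also remains open.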